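The compounds below may be only part of what the source reports. "The series", "measured", "known", "first", "only" and "open" are said of these compounds alone.

Measured so far:
- compound 1 `Cc1cc(=O)oc2cc(Sc3cccc(Cl)n3)ccc12` — 3250 nM
- compound 2 `O=c1ccc2ccc(Oc3no[n+]([O-])c3S(=O)(=O)c3ccccc3)cc2o1` — 8860 nM

In a functional assay on A549 cells (Homo sapiens) for antiproliferative activity, read by MTT assay, with a stated time of 48 h (a higher number here means a weaker inhibitor, a lower number a stronger inhibitor), compound 2 gives 8860 nM and stands as the higher of the two numbers; compound 1 gives 3250 nM, a gap that lies beyond the usual scatter of this assay. The two compounds differ in several places at once, so no single step can be read from them.

Compound 3 `Cc1cc(=O)oc2cc(Oc3no[n+]([O-])c3S(=O)(=O)c3ccccc3)ccc12` is not yet measured. It departs from compound 2 by methyl in place of hydrogen on an aromatic carbon, on an aromatic carbon of a six-membered aromatic ring with 1 oxygen, part of a fused system of two rings, opposite the ring oxygen. Compound 1 carries the same methyl, but its remaining structure differs from compound 3 in other places, so its value is not a guide to this one change.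

For this single methyl on the shared core, compound 3 is expected to land close to compound 2, with the step of a 1.3-fold lower number from compound 2 to compound 3 (0.10 log units; within the scatter) estimated to fall within the scatter or only slightly toward a lower number. The estimate for compound 3 in this assay is 7000 nM, within a range from 3000 nM to 16000 nM.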

Compound 3, half-maximal inhibitory concentration: 5550 nM
Beside the measured number, compound 3's estimate is 1.3-fold (0.10 log units) above it; the measured number falls inside the stated range.
By their numbers in this assay, from the lowest: compounds 1, 3 and 2 (each within the scatter of the next, the first and the last beyond it).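

This is the only pair shown that differs in one place, and it isolates the methyl in place of hydrogen on an aromatic carbon, opposite the ring oxygen. In this assay that change reads as a 1.6-fold lower number from compound 2 to compound 3 (0.20 log units; within the scatter), so compound 2 and compound 3 cannot be told apart and this position carries the methyl with no step beyond the scatter. Nothing measured on these compounds offers an explanation for this result.

As far as these compounds go, whether other groups at this position, such as an ethyl chain, a methoxy group, an amine or a carboxylic acid, would also stay within the scatter remains open. Also open, from the compounds shown here alone, is whether the methyl would read the same way on a different remainder of the molecule, as carried by compound 1.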